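Extending the Ring Group of Compound 3

The source may report more compounds than this note shows. Statements on the series, on what has been measured and on what is new or still open speak of the compounds shown alone.

In a physicochemical assay for solubility, in phosphate buffer, measured as kinetic solubility (a higher number here means a more soluble compound, a lower number a less soluble compound), compound 1 `CC(C)C(c1ccc(-c2ccc3cccc(F)c3c2)[nH]c1=O)C1NC(=O)NC1=O` gives 10600 nM, compound 2 `C/C(=C1/OC(=O)NC1=O)C(c1ccc(-c2ccc3cccc(F)c3c2)[nH]c1=O)C(C)C` gives 17200 nM, and compound 3 `CC(C)C(c1ccc(-c2ccc3cccc(F)c3c2)[nH]c1=O)C1C(=O)NC(=O)N1C` gives 17900 nM. Compound 3 therefore stands within the scatter of both other compounds. Compound 4 `CC(C)C(/C=C1/C(=O)NC(=O)N1C)c1ccc(-c2ccc3cccc(F)c3c2)[nH]c1=O` differs from it thus: a group of 9 heavy atoms (5 carbon, 2 nitrogen, 2 oxygen; one five-membered non-aromatic ring with 2 hetero atoms) in place of a group of 8 heavy atoms (4 carbon, 2 nitrogen, 2 oxygen; one five-membered non-aromatic ring with 2 hetero atoms), on a saturated chain carbon bound to an aromatic carbon and a saturated chain carbon. Two measured steps changed the group at this same place: a 1.6-fold higher number from compound 1 to compound 2 (0.21 log units; within the scatter) and a 1.0-fold higher number from compound 2 to compound 3 (0.02 log units; within the scatter). A third changed that group by a single methyl: a 1.7-fold higher number from compound 1 to compound 3 (0.23 log units; within the scatter). All three stayed within the scatter, so no step beyond the scatter is expected in this assay. The expected change is a 1.2-fold lower number from compound 3 to compound 4 (0.08 log units; within the scatter). The estimated value for compound 4 is 15000 nM, with an expected range from 7000 nM to 30000 nM.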

Compound 4, solubility: 34800 nM
Estimate against measurement, compound 4: 2.3-fold (0.37 log units) below; measured number outside the range, above it.
By their numbers in this assay, from the lowest: compounds 1, 2, 3 and 4 (each within the scatter of the next, the first and the last beyond it).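

In this assay, the group of 9 heavy atoms in compound 4 gives the only steps beyond the scatter among these compounds, both modest: a 2.0-fold higher number from compound 2 to compound 4 (0.31 log units; beyond the scatter) and a 3.3-fold higher number from compound 1 to compound 4 (0.52 log units; beyond the scatter). The step from the closest analogue stays inside it, at a 1.9-fold higher number from compound 3 to compound 4 (0.29 log units; within the scatter), so changing the group at this place can move the number past the scatter, but only when measured against compound 1 or compound 2. Nothing available gives a reason for these steps.

From the compounds shown here alone, whether an amine or a carboxylic acid at this place would shift the number further stays open.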